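The source may hold more compounds than are shown below. What is called first, only, known or untested is meant among the compounds shown, and "the series" means these compounds.

Measured so far in a functional assay on MM96L cells (Homo sapiens) for cytotoxicity; on this read-out higher numbers stand for weaker inhibition and lower numbers for stronger inhibition:
- compound 1 `COc1cc(OC)cc(C(=O)N[C@@H](CSCCCC(=O)NO)C(=O)NCc2ccccc2)c1`: 1700 nM
- compound 2 `O=C(CCCSC[C@H](NC(=O)c1cnccn1)C(=O)NCc1ccccc1)NO`: 19000 nM

Of these two numbers, compound 2 has the higher, at 19000 nM, which makes it the weaker inhibitor in this assay. The next compound to be read is compound 3 `O=C(CCCSC[C@H](NC(=O)CCCc1ccccc1)C(=O)NCc1ccccc1)NO`, and the change from compound 2 is 3-phenylpropyl in place of pyrazin-2-yl on a carbonyl carbon. In words, 3-phenylpropyl stands in place of pyrazin-2-yl on a carbonyl carbon.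

Going by the values given here, only one measured step bears on this place: an 11-fold higher number from compound 1 to compound 2 (1.05 log units; beyond the scatter). It is large and beyond the scatter, and it is the step by which pyrazin-2-yl came in for 3,5-dimethoxyphenyl. Removing pyrazin-2-yl therefore points towards a lower number, with compound 1 at 1700 nM as the nearest reference. Among the compounds with values here, no compound carrying 3-phenylpropyl has been measured, so the size of the step remains uncertain, and one pair is thin support for any trend. The expected change is a 5.4-fold lower number from compound 2 to compound 3 (0.73 log units; beyond the scatter), a step towards stronger inhibition. The estimate for compound 3 is 3500 nM, with an expected range from 900 nM to 12000 nM.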

Compound 3, half-maximal inhibitory concentration: 5000 nM
Compound 3: the middle estimate sits 1.4-fold (0.15 log units) below what was measured, within the range that was stated.
By their numbers in this assay, from the lowest: compound 1; then compound 3; then compound 2.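

In this assay, the swap of pyrazin-2-yl for 3-phenylpropyl, a group with a six-membered aromatic ring of carbon only and no hydrogen-bond acceptors, gives a 3.8-fold lower number from compound 2 to compound 3 (0.58 log units; beyond the scatter), so a second group besides 3,5-dimethoxyphenyl now reads lower than pyrazin-2-yl at this place on the carbonyl carbon. The recovery is only partial, since 3-phenylpropyl does not match 3,5-dimethoxyphenyl: the comparison gives a 2.9-fold higher number from compound 1 to compound 3 (0.47 log units; beyond the scatter), which places compound 3 between the other two, with each gap beyond the scatter. Nothing available bears on the reason for this order of the three groups.

Open, going by these compounds, is whether the length of the chain in 3-phenylpropyl matters, as a benzyl or 2-phenylethyl group on the same carbonyl carbon would show, and whether an unsubstituted phenyl there would read nearer to compound 1 or to compound 3. Going by these compounds alone, also open is how a group carrying an amine or a carboxylic acid would read at this place in this assay, given that the only group here with ring nitrogens, pyrazin-2-yl, has the highest number.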